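A few compounds are considered here, and "the series" means these few. Any claim that something is new, unique, unknown or untested is made for them only; others in the source may bear on it.

For the measured compounds named here, compound 1 `Cn1c(=O)c(S(=O)(=O)c2ccc(F)cc2F)cc2cnc(Nc3ccc4[nH]c(C(=O)O)cc4c3)nc21` is one of three compounds measured in a functional assay on DU-145 cells (Homo sapiens) for inhibition, read by trypan blue exclusion, with a stated time of 72 h; on this read-out higher numbers stand for weaker inhibition and lower numbers for stronger inhibition. Compound 1 gives 10000 nM. Compound 2 `Cn1c(=O)c(S(=O)(=O)c2ccc(F)cc2)cc2cnc(Nc3ccc4[nH]cnc4c3)nc21` gives 10000 nM, level with compound 1 within the scatter of the method. Compound 3 `Cn1c(=O)c(S(=O)(=O)c2ccc(Cl)cc2)cc2cnc(Nc3cnc4[nH]ccc4c3)nc21` gives 5000 nM, and its gap to compound 1 also lies within that scatter, so none of the three stands apart from the others on these numbers.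

Compound 4 `Cc1cc2cc(Nc3ncc4cc(S(=O)(=O)c5ccc(F)cc5F)c(=O)n(C)c4n3)ccc2[nH]1` differs from compound 1 in one place: methyl in place of carboxy on an aromatic carbon. Going by the values given here, no measured pair shows this same change, so its direction cannot be read from the data. The step of a 1.3-fold lower number from compound 1 to compound 4 (0.10 log units; within the scatter) is therefore expected to stay within the scatter. Compound 4 is estimated at 8000 nM, with a range from 2500 nM to 25000 nM.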

Compound 4, half-maximal inhibitory concentration: 750 nM
Estimate against measurement, compound 4: 11-fold (1.03 log units) above; the measured number lies below the stated range.
By their numbers in this assay, from the lowest: compound 4; then compounds 3, 1 and 2 (each within the scatter of the next).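

In this assay, methyl in place of carboxy on this aromatic carbon, next to the ring nitrogen, gives a 13-fold lower number from compound 1 to compound 4 (1.12 log units; beyond the scatter). For the compounds shown here, the group at this position can therefore shift the read-out beyond the scatter, which the earlier compounds could not show, as no two of them differ in one place only. No measurement shown here explains this step.

As far as these compounds go, whether the stronger inhibition comes from having methyl or from losing carboxy remains open. An amine, an ethyl chain or plain hydrogen at this position would help separate the two.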